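Swapping naphthalen-1-yl for 3-methoxyphenyl in a growth-inhibiting series

The source may report more compounds than this note shows. Statements on the series, on what has been measured and on what is new or still open speak of the compounds shown alone.

Compound 1 `COc1ccc(/C=C/C(=O)/C=C/c2ccc(OCc3cn(CCCCOc4cc(=O)oc5ccccc45)nn3)c(OC)c2)cc1OC`: 53%
Compound 2 `COc1ccc(/C=C/C(=O)/C=C/c2ccc(OCc3cn(CCCCCOc4cc(=O)oc5ccccc45)nn3)c(OC)c2)cc1OC`: 43%
Compound 3 `COc1cc(/C=C/C(=O)/C=C/c2cccc3ccccc23)ccc1OCc1cn(CCCCCOc2cc(=O)oc3ccccc23)nn1`: 40%

In a functional assay on COLO 205 cells (Homo sapiens) for inhibition, read by sulforhodamine B assay, with a stated time of 48 h, tested at 50 uM (a higher number here means more inhibition of growth at the concentration tested, a lower number less inhibition of growth), compound 3 gives 40%. This lies within the scatter of compound 2, while compound 1 stands higher, beyond the scatter.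

Compound 4 `COc1cccc(/C=C/C(=O)/C=C/c2ccc(OCc3cn(CCCCCOc4cc(=O)oc5ccccc45)nn3)c(OC)c2)c1` has not yet been measured. It differs from compound 3 in one place: 3-methoxyphenyl in place of naphthalen-1-yl on a double-bonded chain carbon bound to a double-bonded chain carbon. In words, 3-methoxyphenyl takes the place of naphthalen-1-yl on a double-bonded chain carbon bound to a double-bonded chain carbon.

Within the data shown here, only one measured step changes the group at this place, where 3,4-dimethoxyphenyl gives way to naphthalen-1-yl: a number 3 percentage points lower from compound 2 to compound 3 (within the scatter). That step stayed within the scatter, so a single swap here has so far moved this assay very little. One step is thin evidence, but no change beyond the scatter is expected. The estimated change is a number 3 percentage points higher from compound 3 to compound 4 (within the scatter). For compound 4 the expected value is 43%, with an estimated range of 32% to 54%.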

Compound 4, percent growth inhibition at one concentration: 34%
For compound 4 the middle estimate is 9 percentage points above the measured one; measured number inside the range.
By their numbers in this assay, from the lowest: compounds 4, 3, 2 and 1 (each within the scatter of the next, the first and the last beyond it).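

In this assay the two-ring naphthalen-1-yl gives way to the one-ring 3-methoxyphenyl with a number 6 percentage points lower from compound 3 to compound 4 (within the scatter) and so losing a whole aromatic ring at this place has not shifted the reading beyond what repeat measurements would allow. Putting hydrogen in place of one methoxy of the 3,4-dimethoxyphenyl group gives a number 9 percentage points lower from compound 2 to compound 4 (within the scatter) and so this methoxy is not shown to matter here either. Three different groups have now stood at this place on the same chain with no step among them passing the scatter, and nothing measured here explains this.

Still open, on these data alone, is whether a different kind of group here, such as a phenyl ring carrying a dimethylamino group or a carboxylic acid, would move the number beyond the scatter. Also open, as far as these compounds go, is whether these swaps would read the same on the chain of compound 1.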